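Bromo for chloro in two related series

This account rests on a few compounds, and the source may have more. Where it says the series, first, only, none or still open, it means among the compounds named here.

Compound 1 `Cn1c(=O)c2[nH]c(SCC(=O)c3ccc(Cl)cc3)nc2n(C)c1=O` and compound 2 `Cn1c(=O)c2[nH]c(SCC(=O)c3ccc(Br)cc3)nc2n(C)c1=O` share one core; compound 3 `Cn1c(=O)c2[nH]c(SC/C(=N/O)c3ccc(Cl)cc3)nc2n(C)c1=O` and compound 4 `Cn1c(=O)c2[nH]c(SC/C(=N/O)c3ccc(Br)cc3)nc2n(C)c1=O` share another. In a functional assay on A549 cells (Homo sapiens) for inhibition, read by MTT assay, with a stated time of 48 h (a lower number here means a stronger inhibitor, a higher number a weaker inhibitor), compound 1 gives 8400 nM. Compound 2 gives 7900 nM. The change between them, (bromo in place of chloro on an aromatic carbon), produced a 1.1-fold lower number from compound 1 to compound 2 (0.03 log units; within the scatter), so the two values show no meaningful separation.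

Compound 3 gives 1500 nM in this assay, the lowest of the three measured numbers. Against it, the values of compound 1 and compound 2 both stand beyond the scatter, so compound 3 is the strongest inhibitor among the measured set. The difference between the core of compound 1 and the core of compound 3 is not broken down here.

Compound 4 is not yet measured. It differs from compound 3 by bromo in place of chloro on an aromatic carbon, and the place described is word for word the same as for the change from compound 1 to compound 2, so this is the same change made on the second core. On the first core that change gave a 1.1-fold lower number from compound 1 to compound 2 (0.03 log units; within the scatter). Resting on that single precedent, the expected step in this assay is a 1.1-fold lower number from compound 3 to compound 4 (0.03 log units; within the scatter), with the value of compound 3 as anchor because compound 3 gives 1500 nM. Compound 4 is therefore estimated at 1400 nM, with a range expected from 700 nM to 2800 nM.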

Compound 4, half-maximal inhibitory concentration: 1800 nM
Beside the measured number, compound 4's estimate is 1.3-fold (0.11 log units) below it; the range from low to high includes it.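

In this assay the change from 4-chlorophenyl to 4-bromophenyl on the second core gives a 1.2-fold higher number from compound 3 to compound 4 (0.08 log units; within the scatter), and the two steps can be compared directly: the same change on two cores in this assay, a 1.1-fold lower number (0.03 log units; within the scatter) from compound 1 to compound 2 and a 1.2-fold higher number (0.08 log units; within the scatter) from compound 3 to compound 4, 1.3-fold (0.11 log units) apart, within the scatter of two such steps. On these two cores, then, the exchange of chloro for bromo carries over as a step that stays within the scatter each time, and the second core repeats what the first core showed, with no separation of the bromo compound from its chloro partner. The finding rests on two pairs in a single cell assay, so it does not show that the exchange would stay this small on a third core or in another assay, and it gives no explanation of why the chloro and bromo compounds read alike.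

The compounds shown leave open how the numbers in this assay move on either core when the halogen on that aromatic carbon gives way to a group of another kind, such as an amine, a carboxylic acid or a methoxy group. They also leave open whether fluoro or iodo at the same place would follow chloro and bromo.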